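Swapping nitro for fluoro in compound 2

A few compounds are considered here, and "the series" means these few. Any claim that something is new, unique, unknown or untested is made for them only; others in the source may bear on it.

In a functional assay on MIA PaCa-2 cells (Homo sapiens) for cytotoxicity, read by MTT assay, with a stated time of 4 h (a lower number here means a stronger inhibitor, a higher number a weaker inhibitor), compound 2 (`COC1=CC(=O)c2c(COc3ccc([N+](=O)[O-])cc3)c(C)n(C)c2C1=O`) gives 638 nM and compound 1 (`COC1=CC(=O)c2c(c(COc3ccccc3[N+](=O)[O-])c(C)n2C)C1=O`) gives 345 nM so the two lie within the usual scatter of each other. The change to compound 3 (`COC1=CC(=O)c2c(COc3ccc(F)cc3)c(C)n(C)c2C1=O`) puts fluoro in place of nitro on an aromatic carbon. Among the compounds with values here, no measured pair of compounds shows this swap, so any expectation here is loose and the range must stay wide. The expected 1.6-fold higher number from compound 2 to compound 3 (0.20 log units; within the scatter) in this assay is a modest rise in the number, meaning a somewhat weaker inhibitor. For compound 3 the estimated value is 1000 nM (range 300 nM to 3500 nM).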

Compound 3, half-maximal inhibitory concentration: 905 nM
For compound 3 the middle estimate is 1.1-fold (0.04 log units) above the measured one, within the range that was stated.
By their numbers in this assay, from the lowest: compounds 1, 2 and 3 (each within the scatter of the next, the first and the last beyond it).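

In this assay fluoro in place of nitro on this aromatic carbon stays within the scatter (a 1.4-fold higher number from compound 2 to compound 3 (0.15 log units; within the scatter)). A single fluorine can therefore stand where the three heavy atoms and two hydrogen-bond acceptors of nitro stood without a clear shift in the number, which the two nitro compounds could not show. No measurement here explains this result. Open, going by these compounds, is whether an amine or a carboxylic acid on this carbon would also stay within the scatter. Also open, on these data alone, is how fluoro would read at the place that carries nitro in compound 1.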